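Fluoro in place of nitro: expected step

The source may hold more compounds than are shown below. What is called first, only, known or untested is meant among the compounds shown, and "the series" means these compounds.

In a functional assay on U-937 cells (Homo sapiens) for inhibition, read by MTT assay, with a stated time of 72 h (on this read-out lower numbers stand for stronger inhibition and higher numbers for weaker inhibition), compound 1 (`O=C(NO)c1ccc(CNCc2nc(-c3ccccc3)no2)cc1`) gives 7210 nM and compound 2 (`O=C(NO)c1ccc(CNCc2nc(-c3ccc(C(F)(F)F)cc3)no2)cc1`) gives 8050 nM while compound 3 (`O=C(NO)c1ccc(CNCc2nc(-c3ccc([N+](=O)[O-])cc3)no2)cc1`) gives 6520 nM on the same read-out. On these numbers compound 3 stands level with the other two, all three lying within the scatter. The change to compound 4 (`O=C(NO)c1ccc(CNCc2nc(-c3ccc(F)cc3)no2)cc1`) is fluoro in place of nitro on an aromatic carbon. Bearing on it are a 1.1-fold lower number from compound 1 to compound 3 (0.04 log units; within the scatter) and a 1.2-fold lower number from compound 2 to compound 3 (0.09 log units; within the scatter) and also a 1.1-fold higher number from compound 1 to compound 2 (0.05 log units; within the scatter) and each of these stays within the scatter. No step beyond the scatter is therefore expected in this assay for this change. An expected 1.1-fold higher number from compound 3 to compound 4 (0.03 log units; within the scatter) stays inside that scatter. For compound 4 the estimated value is 7000 nM with 3800 nM to 12000 nM as its expected range.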

Compound 4, half-maximal inhibitory concentration: 2950 nM
For compound 4 the middle estimate is 2.4-fold (0.38 log units) above the measured one; the whole stated range lies above it.
By their numbers in this assay, from the lowest: compound 4; then compounds 3, 1 and 2 (each within the scatter of the next).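

In this assay, among the compounds shown here, fluoro is the first group at this position to give a step beyond the scatter, with a 2.2-fold lower number from compound 3 to compound 4 (0.34 log units; beyond the scatter) and a 2.7-fold lower number from compound 2 to compound 4 (0.44 log units; beyond the scatter) and also a 2.4-fold lower number from compound 1 to compound 4 (0.39 log units; beyond the scatter) as modest steps. Compound 1, compound 2 and compound 3 stayed level, so that level reading does not extend to the 4-fluorophenyl group. Nothing available gives a cause for this difference.

As far as these compounds go, whether chloro, methoxy or an amine on that aromatic carbon would stand with fluoro or with the other three groups remains open. From the compounds shown here alone, whether the step persists on a changed core also remains open.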